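A few compounds are considered here, and "the series" means these few. Any claim that something is new, unique, unknown or untested is made for them only; others in the source may bear on it.

Compound 1 `O=S(=O)(/C=C/c1ncccc1F)c1cccc(F)c1`: 474 nM
Compound 2 `O=S(=O)(/C=C/c1ncccc1Cl)c1cccc(F)c1`: 84 nM
Compound 3 `O=S(=O)(/C=C/c1ncccc1F)c1ccc(F)cc1`: 542 nM

All three were tested in an assay on U2OS cells for activation of nuclear factor erythroid 2-related factor 2 (Homo sapiens), read by beta-arrestin recruitment, with a stated time of 6 h; on this read-out lower numbers stand for an effect already at smaller amounts and higher numbers for an effect only at larger amounts of compound. Compound 1 and compound 2 share a core and differ in a single place: chloro in place of fluoro on an aromatic carbon. That change produced a 5.6-fold lower number from compound 1 to compound 2 (0.75 log units; beyond the scatter). Compound 3 is built from the same atoms as compound 1, joined differently; the difference between the two cores is not broken down here. In this assay compound 3 gives 542 nM, and compound 1 gives 474 nM, the two lying within the scatter of each other. Compound 4 `O=S(=O)(/C=C/c1ncccc1Cl)c1ccc(F)cc1` has not yet been measured. It differs from compound 3 in one place: chloro in place of fluoro on an aromatic carbon. The same change therefore appears twice among these compounds, and its surroundings read the same word for word, so it is the same change. Compound 4 is expected to show a step of similar size, a 5.2-fold lower number from compound 3 to compound 4 (0.71 log units; beyond the scatter), because the same change gave a 5.6-fold lower number from compound 1 to compound 2 (0.75 log units; beyond the scatter). Compound 4 is accordingly estimated at 105 nM in this assay, expected to fall between 45 nM and 250 nM.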

Compound 4, half-maximal effective concentration: 231 nM
For compound 4 the middle estimate is 2.2-fold (0.34 log units) below the measured one; measured number inside the range.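

On the second core, chloro in place of fluoro again moved the result in the same direction in this assay, giving a 2.3-fold lower number from compound 3 to compound 4 (0.37 log units; beyond the scatter). Set side by side, the two steps agree in direction, and their sizes cannot be told apart: the same change on two cores in this assay, a 5.6-fold lower number (0.75 log units; beyond the scatter) from compound 1 to compound 2 and a 2.3-fold lower number (0.37 log units; beyond the scatter) from compound 3 to compound 4, 2.4-fold (0.38 log units) apart, within the scatter of two such steps. For these two cores, then, the change carries over, but two pairs are a small sample: they say nothing about how it would behave on a third core, and they do not explain why it lowers the number.

The compounds shown carry only fluoro or chloro on the six-membered aromatic ring with 1 nitrogen, so it remains open how bromo, a methyl group or an amine would read at that same place. Equally open, as far as these compounds go, is whether the chloro step would persist if the fluoro on the other aromatic ring gave way to a group such as a carboxylic acid.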